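From trifluoromethyl to trifluoromethoxy in compound 2

The source may report more compounds than this note shows. Statements on the series, on what has been measured and on what is new or still open speak of the compounds shown alone.

In a functional assay on VCaP cells (Homo sapiens) for antiproliferative activity, read by propidium iodide staining, with a stated time of 96 h (on this read-out lower numbers stand for stronger inhibition and higher numbers for weaker inhibition), compound 1 `CC(O)(COc1ccc(S(F)(F)(F)(F)F)cc1)C(=O)Nc1ccc([N+](=O)[O-])c(C(F)(F)F)c1` gives 100000 nM. Compound 2 `CC(O)(CS(=O)(=O)c1ccccc1C(F)(F)F)C(=O)Nc1cccc(S(F)(F)(F)(F)F)c1` gives 40800 nM, the lower of the two numbers, and the gap between them lies beyond the scatter. Compound 3 `CC(O)(CS(=O)(=O)c1ccccc1OC(F)(F)F)C(=O)Nc1cccc(S(F)(F)(F)(F)F)c1` has trifluoromethoxy in place of trifluoromethyl on an aromatic carbon, ortho to a large group: trifluoromethoxy in place of trifluoromethyl on an aromatic carbon. Going by the values given here, no measured pair shows this change, so the forecast rests on little. The expected step of a 1.1-fold lower number from compound 2 to compound 3 (0.03 log units; within the scatter) stays within the scatter, with no favoured direction. For compound 3 the estimated value is 38000 nM, with an expected range of 13000 nM to 100000 nM.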

Compound 3, half-maximal inhibitory concentration: 13900 nM
Compound 3: middle estimate off by 2.7-fold (0.44 log units), on the high side; the range from low to high includes it.
By their numbers in this assay, from the lowest: compound 3; then compound 2; then compound 1.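

In this assay, putting trifluoromethoxy in place of trifluoromethyl on an aromatic carbon, ortho to a large group, gives a 2.9-fold lower number from compound 2 to compound 3 (0.47 log units; beyond the scatter). This position therefore responds to the change, even though the two groups differ only by one oxygen atom. Nothing measured here explains why the number falls.

This single pair leaves open whether the same swap would have a similar effect elsewhere on these compounds. It also leaves open how an amine, a carboxylic acid or a longer chain such as ethoxy would fare at this position.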